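Swapping the aromatic group: from compound 3 to compound 4

This account rests on a few compounds, and the source may have more. Where it says the series, first, only, none or still open, it means among the compounds named here.

Measured in an ADME assay on HEK293 cells (Homo sapiens) for cytotoxicity, read by MTT assay, with a stated time of 48 h; a lower number here means a stronger inhibitor, a higher number a weaker inhibitor:
- compound 1 `O=C1/C(=C\c2ccc(Cl)cc2)S/C(=N/c2ccccc2)N1Cc1ccncc1`: 42300 nM
- compound 2 `CC(C)c1ccc(/C=C2/S/C(=N/c3ccccc3)N(Cc3ccncc3)C2=O)cc1`: 137000 nM
- compound 3 `COc1ccc(/C=C2/S/C(=N/c3ccccc3)N(Cc3ccncc3)C2=O)cc1OC`: 171000 nM

Compound 3 stands level with compound 2, as a 1.2-fold higher number from compound 2 to compound 3 (0.10 log units; within the scatter) shows. Compound 1 lies clearly lower, as a 4.0-fold higher number from compound 1 to compound 3 (0.61 log units; beyond the scatter) shows. Compound 4 `O=C1/C(=C\c2cccc(O)c2)S/C(=N/c2ccccc2)N1Cc1ccncc1` changes one group, on a double-bonded chain carbon bound to a double-bonded ring carbon: 3-hydroxyphenyl in place of 3,4-dimethoxyphenyl on a double-bonded chain carbon bound to a double-bonded ring carbon. The other swaps on this aromatic group bear on it, and a 3.2-fold higher number from compound 1 to compound 2 (0.51 log units; beyond the scatter) is the same size of move as the step to compound 3 from compound 1. Among the measured compounds shown here, no measured compound carries 3-hydroxyphenyl, so the direction is uncertain. A small step to a lower number seems likeliest, and the expected step is a 2.1-fold lower number from compound 3 to compound 4 (0.33 log units; beyond the scatter). Compound 4 is estimated at 80000 nM, with an expected range from 30000 nM to 190000 nM.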

Compound 4, half-maximal inhibitory concentration: 150000 nM
Compound 4: the middle estimate sits 1.9-fold (0.27 log units) below what was measured; the range from low to high includes it.
By their numbers in this assay, from the lowest: compound 1; then compounds 2, 4 and 3 (each within the scatter of the next).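

In this assay, swapping in 3-hydroxyphenyl, which brings a hydrogen-bond donor, gives no readable change from either 3,4-dimethoxyphenyl (a 1.1-fold lower number from compound 3 to compound 4 (0.06 log units; within the scatter)) or 4-isopropylphenyl (a 1.1-fold higher number from compound 2 to compound 4 (0.04 log units; within the scatter)). Among these four compounds, only 4-chlorophenyl stands apart (a 3.5-fold higher number from compound 1 to compound 4 (0.55 log units; beyond the scatter)), so three quite different groups at this position give numbers within the scatter of one another. Nothing available here accounts for this.

On these data alone, it remains open whether the lower number belongs specifically to chloro, which 4-bromophenyl or 4-fluorophenyl could help test. An amine or a carboxylic acid on this aromatic ring could show whether the level set by the other three groups holds more widely.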